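The compounds below may be only part of what the source reports. "The series", "measured", "known", "first", "only" and "open" are said of these compounds alone.

Three methoxyphenyl compounds on a shared core were tested in a functional assay on A549 cells (Homo sapiens) for cytotoxicity (on this read-out lower numbers stand for an effect already at smaller amounts and higher numbers for an effect only at larger amounts of compound), and gave numbers that lie together. Compound 1 (`COC1=C(C)C(=O)/C(=C(O)/C=C/c2ccc(OC)cc2)C(=O)C1(C)C`) stands at 3 ug/mL and compound 2 (`COC1=C(C)C(=O)/C(=C(O)/C=C/c2cccc(OC)c2)C(=O)C1(C)C`) at 2.8 ug/mL on that read-out, while compound 3 (`COC1=C(C)C(=O)/C(=C(O)/C=C/c2ccccc2OC)C(=O)C1(C)C`) stands at 2.4 ug/mL and so sits level with both. Compound 4 (`COC1=C(C)C(=O)/C(=C(O)/C=C/c2ccc(F)cc2)C(=O)C1(C)C`), not yet measured, differs from compound 3 by one exchange (4-fluorophenyl in place of 2-methoxyphenyl on a double-bonded chain carbon bound to a double-bonded chain carbon), with 4-fluorophenyl in place of 2-methoxyphenyl on a double-bonded chain carbon bound to a double-bonded chain carbon. The measured steps that bear on this only exchange one methoxyphenyl group for another (a 1.1-fold lower number from compound 1 to compound 2 (0.03 log units; within the scatter)), (a 1.3-fold lower number from compound 1 to compound 3 (0.10 log units; within the scatter)), (a 1.2-fold lower number from compound 2 to compound 3 (0.07 log units; within the scatter)), and all three are small. Among the measured compounds shown here, no measured compound carries fluorine, so the exchange itself is untested and the range has to stay wide. In this assay no step beyond the scatter is expected. The estimate means only a small expected step (a 1.2-fold higher number from compound 3 to compound 4 (0.07 log units; within the scatter)). The estimated value for compound 4 is 2.8 ug/mL (expected range 1.3 ug/mL to 6 ug/mL).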

Compound 4, concentration for half-maximal effect: 3.3 ug/mL
For compound 4 the middle estimate is 1.2-fold (0.07 log units) below the measured one; low and high end bracket the measured number.
By their numbers in this assay, from the lowest: compounds 3, 2, 1 and 4 (each within the scatter of the next).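

In this assay, 4-fluorophenyl on a double-bonded chain carbon bound to a double-bonded chain carbon gives no step beyond the scatter against any of the methoxyphenyl groups: a 1.4-fold higher number from compound 3 to compound 4 (0.14 log units; within the scatter), a 1.2-fold higher number from compound 2 to compound 4 (0.07 log units; within the scatter) and a 1.1-fold higher number from compound 1 to compound 4 (0.04 log units; within the scatter). The earlier compounds shown here only moved a methoxy group around its ring, whereas compound 4 has no methoxy group at all, and the last of these steps is the plain exchange of fluoro for methoxy on an aromatic carbon. The number on this read-out therefore does not depend on a methoxy group at this place, and nothing shown offers a reason for this flatness.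

All four compounds carry a substituted phenyl group on the shared core. From the compounds shown here alone, whether an amine or a carboxylic acid on that ring, or a longer chain in its place, would give a step beyond the scatter remains open.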